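Bromo in place of nitro in compound 4

The compounds below may be only part of what the source reports. "The series", "measured", "known", "first", "only" and "open" are said of these compounds alone.

Compound 1 `S=C(N/N=C\c1ccnc2ccccc12)Nc1cccnc1`: 970 nM
Compound 2 `CCc1ccc(NC(=S)N/N=C\c2ccnc3ccccc23)cc1`: 820 nM
Compound 3 `O=[N+]([O-])c1ccc(NC(=S)N/N=C\c2ccnc3ccccc23)cc1`: 810 nM

All three compounds were tested in a functional assay on MCF7 cells (Homo sapiens) for cytotoxicity, read by MTT assay, with a stated time of 48 h; a lower number here means a stronger inhibitor, a higher number a weaker inhibitor. Compound 3 gives 810 nM, which cannot be told apart from the other two values, since all three lie within the scatter of one another. The next compound, compound 4 `S=C(N/N=C\c1ccnc2ccccc12)Nc1ccc(Br)cc1`, keeps the shared core of compound 3 and carries bromo in place of nitro on an aromatic carbon. The group sits on a six-membered aromatic ring of carbon only, para to a large group.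

Within the data shown here, two measured steps bear on this change. The closer one exchanges the group on that same aromatic carbon, with nitro in place of ethyl: a 1.0-fold lower number from compound 2 to compound 3 (0.01 log units; within the scatter). The other places 4-ethylphenyl in place of pyridin-3-yl on an amide-type nitrogen: a 1.2-fold lower number from compound 1 to compound 2 (0.07 log units; within the scatter). Neither step goes beyond the scatter, although bromo itself has not yet been tested in this series. No step beyond the scatter is therefore expected in this assay, and no direction can be favoured. The estimated change is a 1.0-fold lower number from compound 3 to compound 4 (0.01 log units; within the scatter). For compound 4 the expected value is 800 nM, with an estimated range of 450 nM to 1400 nM.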

Compound 4, half-maximal inhibitory concentration: 990 nM
Beside the measured number, compound 4's estimate is 1.2-fold (0.09 log units) below it, within the range that was stated.
By their numbers in this assay, from the lowest: compounds 3, 2, 1 and 4 (each within the scatter of the next).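

In this assay, bromo in place of nitro on this aromatic carbon, para to a large group, gives no separable change (a 1.2-fold higher number from compound 3 to compound 4 (0.09 log units; within the scatter)), and bromo in place of ethyl at the same place gives none either (a 1.2-fold higher number from compound 2 to compound 4 (0.08 log units; within the scatter)). Bromo, a single heavy atom, thus joins nitro and ethyl as a third group on this carbon, and the three compounds that carry them cannot be told apart. The exchange on the amide-type nitrogen also stays within the scatter when 4-bromophenyl replaces pyridin-3-yl (a 1.0-fold higher number from compound 1 to compound 4 (0.01 log units; within the scatter)), and no measurement is at hand that could account for this flat picture.

The compounds shown leave open whether an amine, a carboxylic acid or a longer chain on this same aromatic carbon would produce a step beyond the scatter. They also leave open whether any change to the shared core itself, rather than to the group on its amide-type nitrogen, would separate one compound from another in this assay.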